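The source may hold more compounds than are shown below. What is called first, only, known or untested is meant among the compounds shown, and "the series" means these compounds.

Compound 1 `C#Cc1cn([C@@H]2O[C@H](CO)[C@@H](O)[C@H]2O)c2ncnc(C)c12` gives 5600 nM in a functional assay on CCRF-CEM cells (Homo sapiens), read by MTT assay, with a stated time of 72 h; on this read-out lower numbers stand for stronger inhibition and higher numbers for weaker inhibition. Compound 2 `C#Cc1cn([C@@H]2O[C@H](CO)[C@@H](O)[C@H]2O)c2ncnc(NC)c12` gives only a limit in this assay, > 20000 nM. The step of an at least 3.5-fold higher number from compound 1 to compound 2 (0.55 log units; beyond the scatter) is accordingly known only through (the limit of > 20000 nM in this assay, at which 1 of the 3 values shown sits). Compound 3 `CSc1ncnc2c1c(-c1ccoc1)cn2[C@@H]1O[C@H](CO)[C@@H](O)[C@H]1O` gives 14200 nM, the highest of the two plain numbers shown; the nearest number belongs to compound 1, whose value is lower by more than the scatter. Compound 4 `C#Cc1cn([C@@H]2O[C@H](CO)[C@@H](O)[C@H]2O)c2ncnc(SC)c12` differs from compound 3 by ethynyl in place of furan-3-yl on an aromatic carbon. Among the compounds with values here, no measured step covers this exchange, and the only measured step, an at least 3.5-fold higher number from compound 1 to compound 2 (0.55 log units; beyond the scatter), concerns another position, so no direction beyond the scatter can be predicted. Compound 4 is estimated at 8000 nM, between 3000 nM and 20000 nM. That estimate would mean an expected step of a 1.8-fold lower number from compound 3 to compound 4 (0.25 log units; within the scatter).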

Compound 4, half-maximal inhibitory concentration: > 20000 nM
Compound 4 ended at the assay's limit (the forecaster's own chance of this, stated with the estimate: 20%); at least 2.5-fold (0.39 log units) between middle value and limit.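

Compound 4 gives only a limit in this assay, as compound 2 does: the limit of > 20000 nM in this assay, at which 2 of the 4 values shown sit.

Ethynyl in place of furan-3-yl gives an at least 1.4-fold higher number from compound 3 to compound 4 (0.14 log units; that floor lies within the scatter), so this exchange on the aromatic carbon shows no clear effect, although the true step could be larger. Methylsulfanyl in place of methyl gives an at least 3.5-fold higher number from compound 1 to compound 4 (0.55 log units; beyond the scatter), so it joins methylamino as a second replacement of methyl that weakens inhibition; the step from compound 2 to compound 4 cannot be read.

Still open, going by these compounds, is how a plain amine or an ethyl chain would fare in place of methyl, and how vinyl would compare with ethynyl and furan-3-yl.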